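Methoxyphenyl placement on the aromatic ring nitrogen

This account rests on a few compounds, and the source may have more. Where it says the series, first, only, none or still open, it means among the compounds named here.

Compound 3 `COc1ccc(-n2nncc2CN2C(=O)C3(C(C#N)=C(N)Oc4c3c3nc5ccccc5nc3c3ccccc43)c3ccccc32)cc1` carries a 4-methoxyphenyl on an aromatic nitrogen of the shared core. In a functional assay on A549 cells (Homo sapiens) for antiproliferative activity, read by MTT assay, with a stated time of 48 h (on this read-out lower numbers stand for stronger inhibition and higher numbers for weaker inhibition), compound 3 gives > 50000 nM, which is a limit of the assay and not a number. Its two relatives differing at the same nitrogen are compound 1 `N#CC1=C(N)Oc2c(c3nc4ccccc4nc3c3ccccc23)C12C(=O)N(Cc1cnnn1-c1ccccc1Br)c1ccccc12` with a 2-bromophenyl and compound 2 `N#CC1=C(N)Oc2c(c3nc4ccccc4nc3c3ccccc23)C12C(=O)N(Cc1cnnn1-c1cccc(Br)c1)c1ccccc12` with a 3-bromophenyl. In this assay compound 1 gives > 50000 nM, again only a limit. In this assay compound 2 gives > 50000 nM, also a limit. The steps between these compounds, a step that the two limits leave unreadable from compound 1 to compound 2, a step that the two limits leave unreadable from compound 1 to compound 3 and a step that the two limits leave unreadable from compound 2 to compound 3, therefore cannot be sized; all that is shown is the limit of > 50000 nM in this assay, at which 3 of the 3 values shown sit. Among the compounds with values here, compound 3 thus stands at that limit together with every other value shown, and no measured step offers a readable size.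

Compound 4 `COc1ccccc1-n1nncc1CN1C(=O)C2(C(C#N)=C(N)Oc3c2c2nc4ccccc4nc2c2ccccc32)c2ccccc21` is the next point: 2-methoxyphenyl in place of 4-methoxyphenyl on an aromatic nitrogen. Within the data shown here, no measured step in this assay has a readable size, so nothing argues for a change that would bring the value inside the measurable range. The step that the limit leaves unreadable from compound 3 to compound 4 is estimated to stay within the scatter. Compound 4 is expected to give about 60000 nM, within 20000 nM to 200000 nM, most probably reported once more as a limit.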

Compound 4, half-maximal inhibitory concentration: > 50000 nM
Compound 4: only a limit was reported; the forecaster's own chance of this, stated with the estimate: 85%; the middle value lies beyond the limit too.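

In this assay compound 4 gives > 50000 nM as a limit of the assay and not a number. Its steps from compound 1, compound 2 and compound 3 cannot be read, and the series shows only this: the limit of > 50000 nM in this assay, at which 4 of the 4 values shown sit. The compounds shown leave open whether any aryl group on the aromatic nitrogen brings a value inside the measurable range.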